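This account rests on a few compounds, and the source may have more. Where it says the series, first, only, none or still open, it means among the compounds named here.

Compound 1 `C=CCc1cc(C(C)=O)c(O)cc1OCCCCCCC` gives 31% in an assay on isolated protein for inhibition of leukotriene B4 receptor 1 (Homo sapiens), tested at 10 uM (on this read-out lower numbers stand for less inhibition and higher numbers for more inhibition at the one concentration tested (going by the name of the read-out)), and compound 2 `C#CCCCCOc1cc(O)c(C(C)=O)cc1CC=C` gives 74%. Among the compounds with values here, the step of a number 43 percentage points higher from compound 1 to compound 2 (beyond the scatter) places compound 2 at the higher of the two numbers, with compound 1 as the only other measured compound and its nearest neighbour. Compound 3 `C=CCc1cc(C(C)=O)c(O)cc1OCCCCCC(C)=O` differs from compound 2 at the same place: 2-oxopropyl in place of ethynyl on a saturated chain carbon, four bonds along the chain from an oxygen on an aromatic ring. Within the data shown here, the only measured step that bears on this place is a number 43 percentage points higher from compound 1 to compound 2 (beyond the scatter), which was large and in favour of ethynyl. Since ethynyl now leaves again and the entering 2-oxopropyl has no measured counterpart among these compounds, the expected step is a number 32 percentage points lower from compound 2 to compound 3 (beyond the scatter), a fall back toward the region of compound 1, with wide uncertainty. Compound 3 is therefore expected to give 42% in this assay, with a likely range from 18% to 70%.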

Compound 3, a percentage reported as inhibition, at one concentration (the size of the read-out at that concentration, not a potency): 98%
Compound 3: middle estimate off by 56 percentage points, on the low side; measured number above the stated range.
By their numbers in this assay, from the lowest: compound 1; then compound 2; then compound 3.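

In this assay, ethynyl turns out not to be the best end of this chain: 2-oxopropyl in its place, on a saturated chain carbon, four bonds along the chain from an oxygen on an aromatic ring, gives a number 24 percentage points higher from compound 2 to compound 3 (beyond the scatter). Read against the all-carbon chain, the acetyl end in place of ethyl gives a number 67 percentage points higher from compound 1 to compound 3 (beyond the scatter), so among these compounds both changes to the end of the chain raise the number, and none goes against this. No evidence is at hand on what lies behind the order of these three chain ends.

As far as these compounds go, it remains open whether the carbonyl itself matters, since a hydroxyl, a carboxylic acid or an amine at this place could read differently. From the compounds shown here alone, whether a longer or shorter chain carrying the same acetyl would hold the number also remains open.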